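The source may report more compounds than this note shows. Statements on the series, on what has been measured and on what is new or still open speak of the compounds shown alone.

Compound 1 `C=CC[n+]1ccc(CCC(=O)c2cc3cc(OC)c(OC)cc3s2)cc1` gives 25000 ug/mL in a physicochemical assay for solubility; on this read-out lower numbers stand for lower solubility and higher numbers for higher solubility.
Compound 2 `CCC[n+]1ccc(CCC(=O)c2cc3cc(OC)c(OC)cc3s2)cc1` gives 16000 ug/mL in this assay.
Compound 3 `COc1cc2cc(C(=O)CCc3cc[n+](CC4CCC4)cc3)sc2cc1OC` gives 6000 ug/mL in this assay.

Compound 3 thus stands lowest of the three: a 4.2-fold lower number from compound 1 to compound 3 (0.62 log units; beyond the scatter) and a 2.7-fold lower number from compound 2 to compound 3 (0.43 log units; beyond the scatter) both lie beyond the scatter, while a 1.6-fold lower number from compound 1 to compound 2 (0.19 log units; within the scatter) lies within it. Compound 4 `COCC[n+]1ccc(CCC(=O)c2cc3cc(OC)c(OC)cc3s2)cc1` has not yet been measured in this assay; it differs from compound 3 by methoxymethyl in place of cyclobutyl on a saturated chain carbon bound to an aromatic nitrogen. The measured steps that bear on this change, a 4.2-fold lower number from compound 1 to compound 3 (0.62 log units; beyond the scatter) and a 2.7-fold lower number from compound 2 to compound 3 (0.43 log units; beyond the scatter), were both modest and both lowered the number on arriving at cyclobutyl. Leaving cyclobutyl behind is therefore expected to give a modest rise, a 3.3-fold higher number from compound 3 to compound 4 (0.52 log units; beyond the scatter), though no measured step covers the entering methoxymethyl itself. Compound 4 is estimated at 20000 ug/mL, within a range from 8000 ug/mL to 50000 ug/mL.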

Compound 4, solubility: 33000 ug/mL
Beside the measured number, compound 4's estimate is 1.7-fold (0.22 log units) below it; the measured number falls inside the stated range.
By their numbers in this assay, from the lowest: compound 3; then compounds 2, 1 and 4 (each within the scatter of the next, the first and the last beyond it).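

In this assay, this change at the position on a saturated chain carbon bound to an aromatic nitrogen produces a modest rise (a 5.5-fold higher number from compound 3 to compound 4 (0.74 log units; beyond the scatter)). The earlier compounds shown here held only carbon in this group, and the step to an oxygen, methoxy in place of methyl, also lies beyond the scatter (a 2.1-fold higher number from compound 2 to compound 4 (0.31 log units; beyond the scatter)). Methoxymethyl and vinyl, by contrast, stay within the scatter of each other (a 1.3-fold higher number from compound 1 to compound 4 (0.12 log units; within the scatter)). Nothing shown accounts for these differences. From the compounds shown here alone, whether a hydroxyl, an amine or a longer ether chain at this position would behave like methoxymethyl remains open.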